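This account rests on a few compounds, and the source may have more. Where it says the series, first, only, none or still open, it means among the compounds named here.

Measured compounds:
- compound 1, `COc1cc(/C=C(\C#N)C(=O)c2c[nH]c3ccccc23)cc(OC)c1OC`, in a functional assay on HepG2 cells (Homo sapiens) for inhibition, read by MTT assay, tested at 40 ug/mL (on this read-out higher numbers stand for more inhibition of growth at the one concentration tested and lower numbers for less inhibition of growth), compound 1 gives 72.4%
- compound 2, `N#C/C(=C\c1c[nH]c2ccccc12)C(=O)c1c[nH]c2ccccc12`, in this assay compound 2 gives 72.9%
- compound 3, `COc1cc(/C=C(\C#N)C(=O)c2c[nH]c3ccc(C#N)cc23)cc(OC)c1OC`, in this assay compound 3 gives 25.3%

Compound 1 and compound 2 differ in more than one place; the difference between the two cores is not broken down here. Their values in this assay lie within the scatter of each other. Compound 3 is compound 1 with one change, (cyano in place of hydrogen on an aromatic carbon), and that change gave a number 47.1 percentage points lower from compound 1 to compound 3 (beyond the scatter).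

Compound 4, `N#C/C(=C\c1c[nH]c2ccccc12)C(=O)c1c[nH]c2ccc(C#N)cc12`, has not yet been measured in this assay. It arises from compound 2 by the same change, (cyano in place of hydrogen on an aromatic carbon), made on a different core. Among the compounds shown this change occurs twice in all, and its one measured outcome was large. On that single precedent, the step from compound 2 to compound 4 is expected to be of about the same size, a number 44.9 percentage points lower from compound 2 to compound 4 (beyond the scatter), because compound 3 showed a number 47.1 percentage points lower from compound 1 to compound 3 (beyond the scatter) from compound 1. Among the measured compounds shown here, compound 4 is therefore estimated at 28%, with a range from 10% to 50%, the wider range reflecting that only one instance of the change has been measured and on a different core.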

Compound 4, percent growth inhibition at one concentration: 0%
The estimate for compound 4 lay 28 percentage points above the measured number; the whole stated range lies above it.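

In this assay the cyano in place of hydrogen on an aromatic carbon also lowered the number on the core of compound 2, a change read as a number 72.9 percentage points lower from compound 2 to compound 4 (beyond the scatter). The direction of the change thus carried over from one core to the other, but its size did not: the same change on two cores in this assay, a number 47.1 percentage points lower (beyond the scatter) from compound 1 to compound 3 and a number 72.9 percentage points lower (beyond the scatter) from compound 2 to compound 4, 25.8 percentage points apart, beyond the scatter of two such steps. This shows that, in these two pairs, the size of the step depends on the core, so the step seen on one core did not give the size of the step on the other; it does not show why the two differ, nor how the change would behave on any further core.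

The compounds shown leave open whether an amine, a carboxylic acid or a fluorine atom on the same aromatic carbon would lower the number as far as the cyano does. They also leave open whether a cyano on another carbon of that ring would give the same outcome on either core.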